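The source may hold more compounds than are shown below. What is called first, only, known or untested is meant among the compounds shown, and "the series" means these compounds.

In an assay on HEK293 cells for displacement of a labelled ligand from Urotensin-2 receptor (Homo sapiens) (on this read-out higher numbers stand for weaker inhibition and lower numbers for stronger inhibition), compound 1 `Cn1ccc2c(NC(=O)NCCN3CCC(O)(Cc4ccccc4)CC3)ccnc21` gives 160 nM, while compound 2 `Cc1ccccc1CC1(O)CCN(CCNC(=O)Nc2ccnc3ccsc23)CC1` gives 20 nM, the lower of the two numbers, and the gap between them lies beyond the scatter. Compound 3 `Cc1cccc(CC2(O)CCN(CCNC(=O)Nc3ccnc4ccsc34)CC2)c1` keeps the whole of compound 2 except for one rearrangement: 3-methylphenyl in place of 2-methylphenyl on a saturated chain carbon bound to a saturated ring carbon. For the measured compounds named here, no measured pair shows a shift of this kind, so the direction is open; a small step is expected, perhaps none beyond the scatter. Compound 3 is therefore expected to give about 40 nM, within a range of 10 nM to 160 nM, which means an expected step of a 2.0-fold higher number from compound 2 to compound 3 (0.30 log units; within the scatter) in this assay.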

Compound 3, half-maximal inhibitory concentration: 140 nM
The estimate for compound 3 lay 3.5-fold (0.54 log units) below the measured number; measured number inside the range.
By their numbers in this assay, from the lowest: compound 2; then compounds 3 and 1 (each within the scatter of the next).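

Moving a single methyl group matters in this assay and the swap of 2-methylphenyl for 3-methylphenyl gives a 7.0-fold higher number from compound 2 to compound 3 (0.85 log units; beyond the scatter) with no atom gained or lost. The two groups have the same atoms and the same counts, so this position responds to how those atoms are arranged, not just to which atoms are present. Nothing available explains why this rearrangement changes the number so much.

Still open, going by these compounds, is how 4-methylphenyl or 2-chlorophenyl would behave at this place. On these data alone, it is also open whether 2-methylphenyl would give a similar advantage over 3-methylphenyl on a different core.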